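From 4-methoxyphenyl to 3-cyanophenyl: one open question

The source may hold more compounds than are shown below. What is called first, only, known or untested is meant among the compounds shown, and "the series" means these compounds.

Compound 1 `C=CCc1ccc(OCc2cn(-c3ccccc3Cl)nn2)c(O)c1` gives 46.6%
Compound 2 `C=CCc1ccc(OCc2cn(-c3ccc(OC)cc3)nn2)c(O)c1` gives 62.3%
Compound 3 `C#CCOc1ccc(CC=C)cc1O` gives 27.4%

In a functional assay on MIA PaCa-2 cells (Homo sapiens) for inhibition, read by MTT assay, with a stated time of 72 h, tested at 30 uM (on this read-out lower numbers stand for less inhibition of growth and higher numbers for more inhibition of growth at the one concentration tested), compound 2 stands highest of the three, and its gaps to compound 1 and to compound 3 both lie beyond the usual scatter. Compound 4 (`C=CCc1ccc(OCc2cn(-c3cccc(C#N)c3)nn2)c(O)c1`) differs from compound 2 in one group only (3-cyanophenyl in place of 4-methoxyphenyl on an aromatic nitrogen). In plain words, 3-cyanophenyl takes the place of 4-methoxyphenyl on an aromatic nitrogen. Each group holds one six-membered aromatic ring of carbon only, and the incoming one adds a triple bond outside aromatic rings.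

Just one measured step changes the group at this place (a number 15.7 percentage points higher from compound 1 to compound 2 (beyond the scatter)), with 4-methoxyphenyl replacing 2-chlorophenyl. That step is modest, yet beyond the scatter. Compound 3 lacks this group and offers no comparison. Among the measured compounds shown here, no measured compound carries 3-cyanophenyl, so the direction remains uncertain. For the measured compounds named here, still, the only other group tried here, in compound 1 at 46.6%, sits lower than the one in compound 2, so a modest drop of similar size is expected in this assay. The expected step is a number 12.3 percentage points lower from compound 2 to compound 4 (beyond the scatter), and this is only an estimate. Compound 4 is therefore expected to give about 50%, with an estimated range from 33% to 66%.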

Compound 4, percent growth inhibition at one concentration: 26.6%
The estimate for compound 4 lay 23.4 percentage points above the measured number; measured number outside the range, below it.
By their numbers in this assay, from the lowest: compounds 4 and 3 (each within the scatter of the next); then compound 1; then compound 2.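

In this assay, the swap to 3-cyanophenyl gives a number 35.7 percentage points lower from compound 2 to compound 4 (beyond the scatter) and so opens the largest step yet seen at this position, while the change from 2-chlorophenyl gives a number 20 percentage points lower from compound 1 to compound 4 (beyond the scatter) in the same direction. The outgoing and incoming groups match in heavy atom count, in having one six-membered aromatic ring of carbon only, and in hydrogen-bond donors and acceptors, so these counts alone do not predict the read-out here. The position therefore responds strongly to the choice of group on the phenyl ring, and 4-methoxyphenyl is the best of the three groups compared here, but no evidence at hand explains why.

On these data alone, what remains open is whether the drop follows the nitrile itself or where it sits on the phenyl ring, since the methoxy, chloro and nitrile groups each occupy a different place on that ring in these compounds. It is also unknown how an unsubstituted phenyl ring, an aminophenyl group or a carboxylic acid on the phenyl ring would read at this position.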